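The compounds below may be only part of what the source reports. "The series", "measured", "known", "first", "only" and "open" are said of these compounds alone.

Of the compounds shown here, two have been measured in an assay on HeLa cells for displacement of a labelled ligand from 5-hydroxytryptamine receptor 6 (Homo sapiens) (on this read-out higher numbers stand for weaker inhibition and lower numbers for stronger inhibition), so far. Compound 1 `CN(C)CCn1cc(S(=O)(=O)c2cc(Cl)cc(Cl)c2)c2cccnc21` gives 4.3 nM in this assay. Compound 2 `CN(C)CCn1cc(S(=O)(=O)c2c(Cl)cccc2Cl)c2cccnc21`, which carries a 2,6-dichlorophenyl in place of the 3,5-dichlorophenyl on the sulfonyl sulfur, gives 9 nM; that move is a 2.1-fold higher number from compound 1 to compound 2 (0.32 log units; beyond the scatter). Among the two numbers, compound 2 therefore stands at the weaker end.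

Compound 3 `CN(C)CCn1cc(S(=O)(=O)c2ccc(Cl)s2)c2cccnc21` has not yet been measured. Relative to compound 2 it differs as follows: 5-chlorothiophen-2-yl in place of 2,6-dichlorophenyl on a sulfonyl sulfur. Among the compounds with values here, no measured step involves a thiophene ring, so the only comparison available is the rearrangement of chlorines on a benzene ring, which moved the number only modestly. Because compound 1 sits at 4.3 nM and compound 2 at 9 nM, compound 3 is expected to land near these two, with the step of a 1.5-fold lower number from compound 2 to compound 3 (0.18 log units; within the scatter) judged as within or only just beyond the scatter. The estimate for compound 3 is therefore 6 nM, with a plausible range from 1.5 nM to 25 nM.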

Compound 3, inhibition constant: 3.3 nM
The estimate for compound 3 lay 1.8-fold (0.26 log units) above the measured number; measured number inside the range.
By their numbers in this assay, from the lowest: compounds 3 and 1 (each within the scatter of the next); then compound 2.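

Placing 5-chlorothiophen-2-yl on the sulfonyl sulfur in place of 2,6-dichlorophenyl gives a 2.7-fold lower number from compound 2 to compound 3 (0.44 log units; beyond the scatter) in this assay, so this position accepts not only a benzene ring carrying two chlorines but also a five-membered aromatic ring with one hetero atom and a single chlorine. Against 3,5-dichlorophenyl, the same thiophene gives a 1.3-fold lower number from compound 1 to compound 3 (0.11 log units; within the scatter), so this assay does not separate these two quite different rings, while compound 2 stays apart from both. Nothing available explains these differences.

Going by these compounds, it remains open what a furan or pyridine ring would give on the sulfonyl sulfur with the rest of the structure unchanged. Also open, on these data alone, is what a methyl group would give in place of the chlorine on the thiophene.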